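The compounds below may be only part of what the source reports. "The series", "measured", "known", "first", "only" and "open" are said of these compounds alone.

Of the compounds shown here, two have already been measured in a functional assay on aorta for antagonist activity at Alpha-1D adrenergic receptor (Rattus norvegicus); on this read-out lower numbers stand for tighter binding and higher numbers for weaker binding. Compound 1 `CN(C)C(=O)c1cccnc1NCCCN1CCN(c2ccccc2C#N)CC1` gives 10 nM in this assay. Compound 2 `CN(C)C(=O)c1cccnc1N1CCC(NCCOc2ccccc2-c2cncnc2)CC1` gives 2510 nM in this assay, the higher of the two numbers, and the gap to compound 1 lies well beyond the scatter. Compound 3 `CCOc1ccccc1OCCNC1CCN(c2ncccc2C(=O)N(C)C)CC1` arises from compound 2 by one change: ethoxy in place of pyrimidin-5-yl on an aromatic carbon. Among the compounds with values here, no measured pair shows this change, so the direction is uncertain, but a step that lowers the number is expected, of about an 8.4-fold lower number from compound 2 to compound 3 (0.92 log units; beyond the scatter). The value expected for compound 3 in this assay is 300 nM, within a range from 60 nM to 1500 nM.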

Compound 3, dissociation constant: 15.9 nM
Beside the measured number, compound 3's estimate is 19-fold (1.28 log units) above it; measured number below the stated range.
By their numbers in this assay, from the lowest: compounds 1 and 3 (each within the scatter of the next); then compound 2.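

In this assay, putting ethoxy in place of pyrimidin-5-yl gives a 160-fold lower number from compound 2 to compound 3 (2.20 log units; beyond the scatter) and shows that this one aromatic carbon, ortho to a large group, strongly affects the read-out. The entering group has fewer heavy atoms and no ring, so a low number does not require an aromatic ring at this place. Nothing available explains the size of this step.

Still open, as far as these compounds go, is whether the oxygen, the chain length, or the loss of the ring matters most. Methoxy, or an ethyl group without the oxygen, at the same place would help separate these.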